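The compounds below may be only part of what the source reports. "The series", "measured", "known", "first", "only" and "open" are said of these compounds alone.

Measured compounds:
compound 1 `CNC(=O)c1cc(Oc2ccc(Nc3nccc(N4CCCC4)n3)cc2)ccn1` gives 3720 nM
compound 2 `COc1ccc(C[C@H]2C(=O)N[C@@H](C)C(=O)N(C)[C@H]3Cc4cccc(c4)Oc4cc(ccc4O[C@H]4O[C@H](CO)[C@@H](O)[C@H](O)[C@H]4O)C[C@H](C(=O)N[C@H](C)C(=O)N[C@@H](C)C(=O)N2C)N(C)C3=O)cc1` gives 1850 nM
compound 3 `CN(c1ccc(Oc2ncnc3ccsc23)cc1)c1nccc(N2CCCC2)n1` gives "not determined" (no result reported)

These numbers come from an assay on HEK293T cells for inhibition of nuclear factor NF-kappa-B complex (Homo sapiens), read by a luciferase reporter, with stated times of 6 h and 8 h; on this read-out higher numbers stand for weaker inhibition and lower numbers for stronger inhibition. Among the measured compounds shown here, compound 1 and compound 2 are the only two with a number, and their values lie within the usual scatter of each other, so neither stands apart from the other in this assay. Compound 3 adds nothing to the comparison.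

Compound 4 `CNC(=O)c1cc(Oc2ccc(Nc3nccc(N4CCCCC4)n3)cc2)ccn1` has not yet been measured. Its difference from compound 1 is piperidin-1-yl in place of pyrrolidin-1-yl on an aromatic carbon. For the measured compounds named here, no pair of measured compounds shows what such a change does here, so the expectation for compound 4 rests on the value of compound 1 alone. The step from compound 1 to compound 4 is expected to be a 1.1-fold lower number from compound 1 to compound 4 (0.03 log units; within the scatter), with no move beyond the scatter in either direction. Compound 4 is therefore estimated at 3500 nM, with a range from 1200 nM to 10000 nM.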

Compound 4, half-maximal inhibitory concentration: 840 nM
Beside the measured number, compound 4's estimate is 4.2-fold (0.62 log units) above it, outside the stated range (below it).
By their numbers in this assay, from the lowest: compound 4; then compounds 2 and 1 (each within the scatter of the next).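

Within this assay the change to piperidin-1-yl in place of pyrrolidin-1-yl on this aromatic carbon gives a 4.4-fold lower number from compound 1 to compound 4 (0.65 log units; beyond the scatter) and is the first sign that inhibition responds to this position. The earlier compounds shown here could not show this, since no two of them differed in one place only. Nothing measured here gives a reason for the step. Still open, on these data alone, is what a seven-membered azepan-1-yl ring, a morpholin-4-yl ring or an open-chain dimethylamino group would do at this position. A single pair also leaves open whether the same change would act alike on another core.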